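A Methyl Added to Compound 2

This account rests on a few compounds, and the source may have more. Where it says the series, first, only, none or still open, it means among the compounds named here.

In a functional assay on the whole organism (strain Sprague-Dawley) for inhibition, with Rattus norvegicus as the target, read by paw edema, with a stated time of 180 min, at a dose of 10 mg/kg by the oral route (a higher number here means a stronger effect of the compound at the dose given, a lower number a weaker effect), compound 1 `COc1ccnc(CNc2ccc3c(c2)nc(C)n3C[C@@H](O)[C@H]2O[C@H](O)[C@@H](O)[C@H]2O)c1C` gives 22%, while compound 2 `COc1ccnc(CNc2ccc3[nH]c(C)nc3c2)c1C` gives 11%, the lower of the two numbers, a gap to compound 1 that lies beyond the scatter. Compound 3 `COc1c(C)cnc(CNc2ccc3[nH]c(C)nc3c2)c1C` is compound 2 with a single change: methyl in place of hydrogen on an aromatic carbon. Within the data shown here, no measured pair shows what such a change does, so in this assay the step is expected to be small, within the scatter, with no clear direction. The expected step is a number 3 percentage points higher from compound 2 to compound 3 (within the scatter). Compound 3 is estimated to give 14%, within a range from 0% to 30%.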

Compound 3, a percentage reported as inhibition, in the whole organism at one dose (the size of the read-out at that dose, not a potency): 10%
The estimate for compound 3 lay 4 percentage points above the measured number; measured number inside the range.
By their numbers in this assay, from the lowest: compounds 3 and 2 (each within the scatter of the next); then compound 1.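

In this assay, this first measured pair for the change gives a number 1 percentage points lower from compound 2 to compound 3 (within the scatter), so methyl on this aromatic carbon, ortho to a methoxy group and two atoms from the ring nitrogen, brings no clear shift in the read-out. Nothing measured here speaks to a reason for this result.

As far as these compounds go, whether an ethyl group, an amine or a carboxylic acid on this same carbon would give a different read-out stays open. Also open, from the compounds shown here alone, is whether methyl here would give a similar step on the core of compound 1.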